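Shortening the chain on the carbonyl oxygen: compound 4

This account rests on a few compounds, and the source may have more. Where it says the series, first, only, none or still open, it means among the compounds named here.

Measured so far in an ADME assay on BEAS-2B cells (Homo sapiens) for cytotoxicity, read by MTT assay, with a stated time of 72 h; a lower number here means a stronger inhibitor of growth, a higher number a weaker inhibitor of growth:
compound 1 `CCCOC(=O)Nc1ccc([Se]C#N)cc1` gives 19200 nM
compound 2 `N#C[Se]c1ccc(NC(=O)Oc2ccccc2)cc1` gives 8900 nM
compound 3 `CCCCCCOC(=O)Nc1ccc([Se]C#N)cc1` gives 2800 nM

Compound 3 stands lowest of the three numbers: the step of a 3.2-fold lower number from compound 2 to compound 3 (0.50 log units; beyond the scatter) and the step of a 6.9-fold lower number from compound 1 to compound 3 (0.84 log units; beyond the scatter) both lie beyond the scatter, so compound 3 is the strongest growth inhibitor shown here.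

Compound 4 `CCCCOC(=O)Nc1ccc([Se]C#N)cc1` is the next step from compound 3. The change is hydrogen in place of ethyl on a saturated chain carbon, four bonds along the chain from an oxygen next to a carbonyl group. Among the measured compounds shown here, the only measured step along the same chain is a 6.9-fold lower number from compound 1 to compound 3 (0.84 log units; beyond the scatter), where hydrogen became propyl on a saturated chain carbon, three bonds along the chain from an oxygen next to a carbonyl group, and the number fell modestly. Compound 4 carries a chain between those of compound 1 and compound 3, so a number between what compound 1 gives, 19200 nM, and what compound 3 gives, 2800 nM, is expected, that is a modest rise from compound 3. The expected step is a 3.4-fold higher number from compound 3 to compound 4 (0.53 log units; beyond the scatter). For compound 4 the estimate in this assay is 9500 nM, with a range from 4000 nM to 22000 nM.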

Compound 4, concentration for 50% growth inhibition: 5000 nM
The estimate for compound 4 lay 1.9-fold (0.28 log units) above the measured number, within the range that was stated.
By their numbers in this assay, from the lowest: compounds 3, 4 and 2 (each within the scatter of the next, the first and the last beyond it); then compound 1.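

In this assay, going from the hexyl chain to the butyl chain leaves the number within the scatter (a 1.8-fold higher number from compound 3 to compound 4 (0.25 log units; within the scatter)), so losing ethyl at this position, four bonds along the chain from the oxygen, cannot be told apart from no change. Butyl and phenyl on that oxygen are not separated either (a 1.8-fold lower number from compound 2 to compound 4 (0.25 log units; within the scatter)). The step that can be read along the chain is propyl to butyl, methyl in place of hydrogen three bonds along the chain from the oxygen (a 3.8-fold lower number from compound 1 to compound 4 (0.58 log units; beyond the scatter)), which lies beyond the scatter.

On these data alone, whether a longer chain than hexyl, or an amine or a carboxylic acid at the chain end, would shift the number stays open. The data shown give no reason for any of these steps.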